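The source may hold more compounds than are shown below. What is called first, only, known or untested is meant among the compounds shown, and "the series" means these compounds.

Compound 1 `C=CCc1cc(OC)c(OC(C)C(OCCCCCCCC)c2ccc(O)c(OC)c2)c(OC)c1`: 86 nM
Compound 2 `C=CCc1cc(OC)c(OC(C)C(OC)c2ccc(O)c(OC)c2)c(OC)c1`: 3450 nM

Among the measured compounds shown here, in an assay on HEK293 cells for agonist activity at transient receptor potential cation channel subfamily M member 8 (Homo sapiens), read by fluorescence and calcium flux, with a stated time of 5 min (a lower number here means that less compound is needed, a higher number that more compound is needed for the effect), compound 2 stands at the higher of the two numbers recorded; the only measured step that bears on it is a 40-fold higher number from compound 1 to compound 2 (1.60 log units; beyond the scatter), a large one. Compound 3 `C=CCc1cc(OC)c(OC(C)C(OCC(C)C)c2ccc(O)c(OC)c2)c(OC)c1` carries isopropyl in place of hydrogen on a saturated chain carbon bound to an oxygen on a saturated carbon, a change at the same position as that step, but reaching only part of the way toward the chain of compound 1. A move back in the opposite direction, of smaller size, is therefore expected. Compound 3 is estimated at 600 nM (range 150 nM to 2000 nM), corresponding to a 5.8-fold lower number from compound 2 to compound 3 (0.76 log units; beyond the scatter).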

Compound 3, half-maximal effective concentration: 138 nM
Compound 3: the middle estimate sits 4.3-fold (0.64 log units) above what was measured; the whole stated range lies above it.
By their numbers in this assay, from the lowest: compounds 1 and 3 (each within the scatter of the next); then compound 2.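

In this assay, isopropyl in place of hydrogen on a saturated chain carbon bound to an oxygen on a saturated carbon gives a 25-fold lower number from compound 2 to compound 3 (1.40 log units; beyond the scatter), so the full length of the heptyl of compound 1 is not needed for most of the gain. Heptyl and isopropyl are not separated here, with a 1.6-fold higher number from compound 1 to compound 3 (0.21 log units; within the scatter), and no order can be stated between them. Nothing available explains the size of these steps. Still open, going by these compounds, is how a chain longer than heptyl, or a cyclohexyl ring, would read at this place. An amine or a carboxylic acid on the chain also remains to be placed.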